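Series notes: an amine in place of an ether

The source may hold more compounds than are shown below. What is called first, only, known or untested is meant among the compounds shown, and "the series" means these compounds.

In a functional assay on M14 cells (Homo sapiens) for inhibition, read by sulforhodamine B assay, with a stated time of 48 h (a lower number here means a stronger inhibitor of growth, a higher number a weaker inhibitor of growth), compound 1 `Nc1cc(N)c2nc(-c3ccccc3)c(Oc3ccc(Cl)c(Cl)c3)nc2c1` gives 14100 nM. Compound 3 `COc1cc(CNc2nc3cc(N)cc(N)c3nc2-c2ccccc2)cc(OC)c1OC` gives 9550 nM, which lies within the scatter of compound 1, while compound 2 `CCOC(=O)[C@H](CCC(=O)O)NC(=O)c1ccc(CNc2nc3cc(N)cc(N)c3nc2-c2ccccc2)cc1` gives 45700 nM, a number higher than that of compound 1 by more than the scatter; compound 1 thus stands second highest of the three values. Compound 4 `Nc1cc(N)c2nc(-c3ccccc3)c(NCc3ccc(F)cc3)nc2c1` is not yet measured; its change from compound 1 is (4-fluorobenzyl)amino in place of 3,4-dichlorophenoxy on an aromatic carbon. Among the measured compounds shown here, no step between measured compounds isolates this change. The step is expected to be small, in either direction or none beyond the scatter, because compound 3 gives 9550 nM with a related benzylamino group on the shared core. The value of compound 4 is estimated at 10000 nM (3000 nM to 30000 nM). This corresponds to an expected step of a 1.4-fold lower number from compound 1 to compound 4 (0.15 log units; within the scatter).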

Compound 4, concentration for 50% growth inhibition: 23400 nM
The estimate for compound 4 lay 2.3-fold (0.37 log units) below the measured number, and the stated range covers the measured number.
By their numbers in this assay, from the lowest: compounds 3, 1, 4 and 2 (each within the scatter of the next, the first and the last beyond it).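

At the aromatic carbon next to the ring nitrogen, (4-fluorobenzyl)amino in place of 3,4-dichlorophenoxy gives a 1.7-fold higher number from compound 1 to compound 4 (0.22 log units; within the scatter) in this assay. This position therefore accepts the exchange of an aryl ether for a benzylamine, with its added hydrogen-bond donor, without a step beyond the scatter. Nothing at hand bears on the reason for this reading.

The linking atoms and the ring halogens change together, so their separate contributions remain unresolved. On these data alone, how a piperazine or a plain alkylamine would read at this position also remains open.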